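The compounds below may be only part of what the source reports. "The series", "measured", "known", "first", "only" and "open" are said of these compounds alone.

Measured compounds:
compound 1 `CCCS(=O)(=O)N1CC=C(c2ccc3c(c2)CC(C2CCN(Cc4ccccc4)CC2)O3)CC1` — 88%
compound 2 `CCCS(=O)(=O)N1CC=C(c2ccc3c(c2)CC(C2CCN(S(=O)(=O)CCC)CC2)O3)CC1` — 43%
compound 3 `CCCS(=O)(=O)N1CC=C(c2ccc3c(c2)CC(C2CCN(C(=O)OC4CCCCC4)CC2)O3)CC1` — 56%

All three were tested in a functional assay on HEK293 cells with Glucose-dependent insulinotropic receptor (Homo sapiens) as the target, read by cAMP accumulation, with a stated time of 60 min (on this read-out lower numbers stand for smaller maximal responses and higher numbers for larger maximal responses), and all share one core; they differ only in the group carried on an amine nitrogen in a ring. Among the three, compound 3 stands second highest: compound 2 lies nearest, and the step of a number 13 percentage points higher from compound 2 to compound 3 (beyond the scatter) is modest, while compound 1 lies furthest, since the step of a number 32 percentage points lower from compound 1 to compound 3 (beyond the scatter) is large. The largest step altogether is a number 45 percentage points lower from compound 1 to compound 2 (beyond the scatter).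

Compound 4 `CCCS(=O)(=O)N1CC=C(c2ccc3c(c2)CC(C2CCN(c4ncc(Cl)cn4)CC2)O3)CC1` has not yet been measured. It arises from compound 3 by one change: 5-chloropyrimidin-2-yl in place of cyclohexyloxycarbonyl on an amine nitrogen in a ring.

The steps already seen bear on this position, since each of them also swaps the group on the same amine nitrogen, and they show that such a swap can move the maximal response by a large amount in either direction. None of them introduces an aromatic ring bound directly to that nitrogen, so the direction for compound 4 is uncertain, and the expected step in this assay is a number 6 percentage points higher from compound 3 to compound 4 (within the scatter), which is within the scatter. Compound 4 is therefore estimated to give 62%, within a range from 35% to 90%.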

Compound 4, largest response reached (Emax), in percent of the reference or control that the assay uses: 88%
Estimate against measurement, compound 4: 26 percentage points below, and the stated range covers the measured number.
By their numbers in this assay, from the lowest: compound 2; then compound 3; then compounds 1 and 4 (each within the scatter of the next).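

In this assay putting 5-chloropyrimidin-2-yl in place of cyclohexyloxycarbonyl on the amine nitrogen in a ring gives a number 32 percentage points higher from compound 3 to compound 4 (beyond the scatter) and shows that an aromatic ring bound directly to this nitrogen is compatible with a large maximal response. The same group gives a number 45 percentage points higher from compound 2 to compound 4 (beyond the scatter) when it replaces propylsulfonyl and no change at the digits printed from compound 1 to compound 4 (within the scatter) when it replaces benzyl, so among these four compounds the two groups that carry an aromatic ring, in compound 1 and compound 4, stand level with each other and apart from the two that carry none, in compound 2 and compound 3. Nothing measured here explains why the maximal response follows this pattern.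

As far as these compounds go, it remains open whether the chlorine matters, and a pyrimidin-2-yl group without chlorine or a plain phenyl ring on the same nitrogen would help to separate the contribution of the ring from that of the chlorine. Also open, from the compounds shown here alone, is what maximal response the free amine would give, with only a hydrogen on that nitrogen.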